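This account rests on a few compounds, and the source may have more. Where it says the series, first, only, none or still open, it means among the compounds named here.

Compound 1 `CCn1ncnc1-c1ccccc1NCC1=NCCN1` gives 94% in a functional assay with Alpha-1B adrenergic receptor (Homo sapiens) as the target, read by calcium flux; a higher number here means a larger maximal response, a lower number a smaller maximal response.
Compound 2 `CCn1cccc1-c1ccccc1NCC1=NCCN1` gives 0% in this assay.

Of the two measured compounds, compound 1 stands highest in this assay; compound 2 lies far below it, and that gap is beyond the usual scatter. Compound 3 `CCCn1ncnc1-c1ccccc1NCC1=NCCN1` has not been measured. It differs from compound 1 by methyl in place of hydrogen on a saturated chain carbon, two bonds along the chain from an aromatic nitrogen, so the chain grows from ethyl to propyl. Within the data shown here, with no measured step of this kind to lean on, the step of a number 9 percentage points lower from compound 1 to compound 3 (within the scatter) is expected to be small, likely within the scatter, perhaps a slight fall. Compound 3 is therefore estimated at 85%, within a range of 60% to 100%.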

Compound 3, largest response reached (reported as maximal response), in percent of the reference or control that the assay uses: 74%
Compound 3: middle estimate off by 11 percentage points, on the high side; measured number inside the range.
By their numbers in this assay, from the lowest: compound 2; then compound 3; then compound 1.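

In this assay, growing the chain from ethyl to propyl brings a number 20 percentage points lower from compound 1 to compound 3 (beyond the scatter), so this position is sensitive to a single added methyl. The change lowers the response without abolishing it: compound 3 at 74% still keeps a substantial maximal response. Nothing available here explains this fall.

On these data alone, whether a longer chain such as butyl would lower the response further remains open. So does whether a branched isopropyl or a cyclopropyl group at this position would behave as propyl does.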